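A few compounds are considered here, and "the series" means these few. Any claim that something is new, unique, unknown or untested is made for them only; others in the source may bear on it.

- Compound 1 `C/C=C/COc1cc(/C=C\c2cc(OC)c(OC)c(OC)c2)ccc1OC`: 5400 nM
- Compound 2 `COc1ccc(COc2cc(/C=C\c3cc(OC)c(OC)c(OC)c3)ccc2OC)cc1`: 48000 nM
- Compound 3 `COc1cccc(/C=C/CCCOc2cc(/C=C\c3cc(OC)c(OC)c(OC)c3)ccc2OC)c1`: 41000 nM

All three were tested in a functional assay on MCF7 cells (Homo sapiens) for inhibition, read by MTT assay, with a stated time of 3 days; a lower number here means a stronger inhibitor, a higher number a weaker inhibitor. Compound 3 stands with compound 2 at the weak end of this small set, and the gap to compound 1 is clear: a 7.6-fold higher number from compound 1 to compound 3 (0.88 log units; beyond the scatter). Compound 4 `COc1ccc(/C=C\c2cc(OC)c(OC)c(OC)c2)cc1OCCC/C=C/c1ccc(Cl)cc1` changes only the ring at the end of the chain, with 4-chlorophenyl in place of 3-methoxyphenyl on a double-bonded chain carbon bound to a double-bonded chain carbon.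

Within the data shown here, no measured step isolates this swap. The closest guide is that replacing one ring-bearing group with another changed little: a 1.2-fold lower number from compound 2 to compound 3 (0.07 log units; within the scatter). Dropping the ring-bearing group mattered more: an 8.9-fold higher number from compound 1 to compound 2 (0.95 log units; beyond the scatter). Compound 4 keeps a ring, so no change beyond the scatter is expected, and the estimated step is a 1.2-fold lower number from compound 3 to compound 4 (0.07 log units; within the scatter). Compound 4 is estimated at 35000 nM, with an expected range from 14000 nM to 85000 nM.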

Compound 4, half-maximal inhibitory concentration: 40000 nM
The estimate for compound 4 lay 1.1-fold (0.06 log units) below the measured number; low and high end bracket the measured number.
By their numbers in this assay, from the lowest: compound 1; then compounds 4, 3 and 2 (each within the scatter of the next).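

At the end of the but-3-en-1-yl chain, 4-chlorophenyl reads the same as 3-methoxyphenyl (a 1.0-fold lower number from compound 3 to compound 4 (0.01 log units; within the scatter)), so losing the methoxy oxygen and its hydrogen-bond acceptor shows no effect here. The new chain also sits level with the 4-methoxyphenyl group of compound 2 (a 1.2-fold lower number from compound 2 to compound 4 (0.08 log units; within the scatter)), while the gap to the prop-1-en-1-yl group of compound 1 remains (a 7.4-fold higher number from compound 1 to compound 4 (0.87 log units; beyond the scatter)). Nothing available explains this pattern. Still open, from the compounds shown here alone, is whether an amine or a carboxylic acid on the end ring would shift the number, and whether 4-chlorophenyl behaves alike on a shorter chain.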